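Benzyl in place of benzyloxymethyl on the cyclic sulfamide core

A few compounds are considered here, and "the series" means these few. Any claim that something is new, unique, unknown or untested is made for them only; others in the source may bear on it.

Compound 1 `O=C1c2ccccc2N(Cc2ccccc2)S(=O)(=O)N1COCc1ccccc1` is the starting point of this step. In a functional assay on HEL cells (Homo sapiens) (on this read-out lower numbers stand for higher toxicity in this test and higher numbers for lower toxicity in this test), compound 1 gives 49000 nM, the lowest of the two numbers that are available; the nearest number is that of compound 3 `O=C1c2ccccc2N(Cc2ccccc2Cl)S(=O)(=O)N1Cc1ccccc1`, which gives 200000 nM, a gap that lies beyond the scatter. Compound 2 `O=C1c2ccccc2N(Cc2ccccc2Cl)S(=O)(=O)N1Cc1ccccc1Cl` gives only a limit of the assay, > 20000 nM. For the measured compounds named here, the one measured step, a step that the limit leaves unreadable from compound 2 to compound 3, is therefore not readable in size, as the limit of > 20000 nM in this assay, at which 1 of the 3 values shown sits, sets its lower bound only.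

Compound 4 `O=C1c2ccccc2N(Cc2ccccc2)S(=O)(=O)N1Cc1ccccc1` differs from compound 1 by phenyl in place of benzyloxy on a saturated chain carbon bound to an amide-type nitrogen in a ring. Going by the values given here, no measured step touches this change, so the expectation rests on the shared core and on compound 3, whose 200000 nM carries the same benzyl on that nitrogen. The step is expected to be modest, toward a somewhat higher number, a 2.0-fold higher number from compound 1 to compound 4 (0.31 log units; beyond the scatter), though within scatter of no change cannot be excluded. Compound 4 is therefore estimated at 100000 nM, ranging from 30000 nM to 300000 nM.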

Compound 4, minimum cytotoxic concentration: > 50000 nM
Compound 4: no number, only a limit; the forecaster's own chance of this, stated with the estimate: 25%; the middle value does not contradict the limit.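

In this assay compound 4 gives only a limit of the assay, not a number: the limit of > 50000 nM in this assay, at which 1 of the 4 values shown sits. For phenyl in place of benzyloxy on a saturated chain carbon bound to an amide-type nitrogen in a ring, the reading is an at least 1.0-fold higher number from compound 1 to compound 4 (0.00 log units; that floor lies within the scatter), which sets a floor for this change and not a size. The steps that involve a limit, including the one between the two benzyl compounds that differ by chloro, cannot be read, so the new compound adds no readable chloro comparison.

Still open, from the compounds shown here alone, are the real size of the change from (benzyloxy)methyl to benzyl and whether chloro on an aromatic carbon moves the read-out at all. Also open, going by these compounds, is how a longer chain, an amine or a carboxylic acid at this position would read in this assay.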